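Removing the Carboxy Group from a Methoxy Amidine

The source may report more compounds than this note shows. Statements on the series, on what has been measured and on what is new or still open speak of the compounds shown alone.

Compound 1, `COCCNC(=N)NCCC(C)C`: 20%
Compound 2, `COCC(=N)NCCC[C@H](N)C(=O)O`: 22%

In an assay for inhibition of arginase-1 (Bos taurus), with a stated time of 30 min, tested at 1 mM (on this read-out higher numbers stand for more inhibition at the one concentration tested (going by the name of the read-out) and lower numbers for less inhibition), compound 1 gives 20% and compound 2 gives 22%; the two numbers lie within the usual scatter of each other, so nothing separates them. Compound 3, `COCC(=N)NCCCCN`, is not yet measured. It differs from compound 2 by hydrogen in place of carboxy on a saturated chain carbon bound to an amine nitrogen and a saturated chain carbon. Among the compounds with values here, no step between measured compounds is available to set the size of such a change. The expected step is a number 14 percentage points lower from compound 2 to compound 3 (beyond the scatter), a loss of inhibition beyond the scatter. Compound 3 is estimated at 8%, with a range from 0% to 25%.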

Compound 3, a percentage reported as inhibition, at one concentration (the size of the read-out at that concentration, not a potency): 21%
For compound 3 the middle estimate is 13 percentage points below the measured one; the measured number falls inside the stated range.
By their numbers in this assay, from the lowest: compounds 1, 3 and 2 (each within the scatter of the next).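

In this assay hydrogen in place of carboxy on a saturated chain carbon bound to an amine nitrogen and a saturated chain carbon gives a number 1 percentage points lower from compound 2 to compound 3 (within the scatter) and so shows that, at the one concentration tested, this read-out does not separate the compounds with and without the carboxy group. Nothing at hand gives a reason for this result. The compounds shown leave open how a methyl ester or a primary amide at this carbon would read. They also leave open what a longer chain would do.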